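Replacing the oxopyrrolidinyl group of compound 2

The source may report more compounds than this note shows. Statements on the series, on what has been measured and on what is new or still open speak of the compounds shown alone.

In a physicochemical assay for solubility, read by LC-MS, in phosphate buffer, with a stated time of 24 h, at pH 7.4 (a higher number here means a more soluble compound, a lower number a less soluble compound), compound 1 `O=C(Nc1ccccc1)c1cnc(NCc2c(F)ccc3c2CCO3)n2cnnc12` gives < 1000 nM, which is a limit of the assay and not a number. Within the data shown here, compound 2 `CC1(C)CC(=O)N(c2cnc(NCc3c(F)ccc4c3CCO4)n3cnnc23)C1` reaches 57000 nM, the only actual number so far. Compound 3 `CN(c1ccn(C)n1)c1cnc(NCc2c(F)ccc3c2CCO3)n2cnnc12` carries methyl(1-methyl-1H-pyrazol-3-yl)amino in place of 4,4-dimethyl-2-oxopyrrolidin-1-yl on the same aromatic carbon: methyl(1-methyl-1H-pyrazol-3-yl)amino in place of 4,4-dimethyl-2-oxopyrrolidin-1-yl on an aromatic carbon. Among the measured compounds shown here, one measured step bears on this change, an at least 57-fold higher number from compound 1 to compound 2 (1.75 log units; beyond the scatter). It is large, lies beyond the scatter and concerns the same carbon, but its entering group is the one now leaving, and the new group has not been measured. It therefore guides the direction only loosely. A moderate fall is expected, much smaller than that step, with an estimated size of a 2.9-fold lower number from compound 2 to compound 3 (0.45 log units; beyond the scatter). The estimate for compound 3 is 20000 nM, with an expected range of 5000 nM to 60000 nM.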

Compound 3, solubility: 130000 nM
Compound 3: the middle estimate sits 6.5-fold (0.81 log units) below what was measured; the whole stated range lies below it.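

In this assay, 4,4-dimethyl-2-oxopyrrolidin-1-yl does not mark the top of the range at this aromatic carbon: methyl(1-methyl-1H-pyrazol-3-yl)amino in its place gives a 2.3-fold higher number from compound 2 to compound 3 (0.36 log units; beyond the scatter). The entering group has no carbonyl and carries an aromatic ring in place of a non-aromatic one, so a high number at this carbon does not require the ring carbonyl of compound 2. The other new step, an at least 130-fold higher number from compound 1 to compound 3 (2.11 log units; beyond the scatter), is only a bound, since compound 1 stands at a limit of the assay and not at a number: the limit of < 1000 nM in this assay, at which 1 of the 3 values shown sits.

The compounds shown do not separate the contribution of the pyrazole ring from that of the methyl on its linking nitrogen. They also leave open how a morpholine ring or a simple dimethylamino group would read at this carbon.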